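The source may report more compounds than this note shows. Statements on the series, on what has been measured and on what is new or still open speak of the compounds shown alone.

In a physicochemical assay for acid dissociation, compound 2 `COc1cccc(CNCCCNc2ccnc3cc(Cc4cccc(C(F)(F)F)c4)ccc23)c1O` gives 9.47, the higher of the two numbers in hand, while compound 1 `CN(C)c1cccc(Oc2ccc3c(NCCCNCc4ccco4)ccnc3c2)c1` gives 9.28, a value that sits within the scatter of it, so no order between the two is claimed. Compound 3 `COc1cccc(CNCCCNc2ccnc3cc(Oc4cccc(N(C)C)c4)ccc23)c1O` is not yet measured. It differs from compound 2 by 3-(dimethylamino)phenoxy in place of 3-(trifluoromethyl)benzyl on an aromatic carbon. Among the measured compounds shown here, no measured pair covers this exchange. Compound 1 already carries the same 3-(dimethylamino)phenoxy group and gives 9.28, so no step beyond the scatter is expected. The expected step is a number 0.07 log units lower from compound 2 to compound 3 (within the scatter). For compound 3 the estimate in this assay is 9.4, with a range of 9 to 9.8.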

Compound 3, acid dissociation constant: 9.28
The estimate for compound 3 lay 0.12 log units above the measured number; the range from low to high includes it.
By their numbers in this assay, from the lowest: compounds 1, 3 and 2 (each within the scatter of the next).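

In this assay the exchange of 3-(trifluoromethyl)benzyl for 3-(dimethylamino)phenoxy on the aromatic carbon reads a number 0.19 log units lower from compound 2 to compound 3 (within the scatter) and gives the first step read at this position. The exchange of furan-2-yl for 2-hydroxy-3-methoxyphenyl on the saturated chain carbon bound to an amine nitrogen reads no change at the digits printed from compound 1 to compound 3 (within the scatter), so neither place has yet given a step beyond the scatter. No evidence on the cause accompanies these numbers. From the compounds shown here alone, whether a carboxylic acid or a morpholine in place of 3-(dimethylamino)phenoxy would give such a step stays open. Which atom in these compounds the number belongs to also stays open.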